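Notes on the quinone series: outlook for compound 4

This account rests on a few compounds, and the source may have more. Where it says the series, first, only, none or still open, it means among the compounds named here.

Measured so far:
compound 1 `COC1=CC(=O)C(O)=C(C/C=C(\C)CC[C@@]2(C)CCC=C(C)[C@H]2C)C1=O` gives > 10 ug/mL in an ADME assay on KB cells (Homo sapiens) for cytotoxicity, with a stated time of 48 h; a higher number here means a weaker inhibitor, a lower number a stronger inhibitor
compound 2 `CC1=CCC[C@H]2[C@](C)(CC3=C(O)C(=O)C=C(N[C@@H](CO)C(=O)O)C3=O)[C@@H](C)CC[C@]12C` gives 7.6 ug/mL
compound 3 `C=C1[C@H](C)CCC[C@]1(C)CC/C(C)=C/CC1=C(O)C(=O)C=C(N[C@H](C(=O)O)C(C)C)C1=O` gives > 10 ug/mL

Compound 1 is recorded only as a limit, not a number. Compound 3 likewise is recorded only as a limit. For the measured compounds named here, compound 1 therefore stands at the limit of > 10 ug/mL in this assay, at which 2 of the 3 values shown sit, with compound 2 the only member that returns a number, and that number lies close to the same limit.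

Compound 4 `CC1=CCC[C@](C)(CC/C(C)=C/CC2=C(O)C(=O)C=C(N[C@H](C(=O)O)[C@H](C)O)C2=O)[C@@H]1C` differs from compound 1 in one place: (1-carboxy-2-hydroxypropyl)amino in place of methoxy on a double-bonded ring carbon. Compound 2 and compound 3 carry amino-acid groups of the same kind on the shared core, one returning a number near the limit and one returning the limit itself. Going by the values given here, no step between measured compounds is available to size the change.

The step of an at least 1.1-fold lower number from compound 1 to compound 4 (0.04 log units; that floor lies within the scatter) is expected to be small, either none beyond the scatter or a modest move toward a stronger inhibitor, in line with compound 2 and its 7.6 ug/mL. Compound 4 is estimated at 9 ug/mL, with a range from 4.5 ug/mL to 20 ug/mL, and a real chance that only a limit is reported.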

Compound 4, half-maximal inhibitory concentration: > 10 ug/mL
Compound 4: no number, only a limit; the forecaster's own chance of this, stated with the estimate: 45%; at least 1.1-fold (0.04 log units) between middle value and limit.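

For the compounds shown here, compound 1 and compound 4 are both recorded only as limits, and no step between them can be read. The compounds shown leave open whether (1-carboxy-2-hydroxypropyl)amino in place of methoxy moves the result in this assay at all, and in which direction.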